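A few compounds are considered here, and "the series" means these few. Any claim that something is new, unique, unknown or untested is made for them only; others in the source may bear on it.

Measured compounds in an ADME assay on WI-38 cells (Homo sapiens) for cytotoxicity, read by MTT assay, with a stated time of 72 h; on this read-out lower numbers stand for stronger inhibition and higher numbers for weaker inhibition:
compound 1 `O=C(NC/C=C\Cn1cc(F)c(=O)[nH]c1=O)c1ccccc1`: > 100000 nM, a limit of the assay rather than a number.
compound 2 `Nc1ccn(C/C=C\CNC(=O)c2ccccc2)c(=O)n1`: 4200 nM.
compound 3 `Cc1cn(C/C=C\CNC(=O)c2ccc(F)cc2)c(=O)[nH]c1=O`: 100 nM.

Compound 2 holds the highest of the two actual numbers in this assay; compound 3 lies far lower, and that gap is beyond the usual scatter. Compound 1 sits at the limit of > 100000 nM in this assay, at which 1 of the 3 values shown sits, so it gives no number to compare.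

Compound 4 `Nc1ccn(C/C=C\CNC(=O)c2ccc(F)cc2)c(=O)n1` is not yet measured. It differs from compound 2 by fluoro in place of hydrogen on an aromatic carbon. Within the data shown here, no measured pair isolates this change: compound 3 carries the 4-fluorophenyl, but on a different core, so the distance between compound 3 and compound 2 cannot be read as the effect of the fluoro alone. The step of a 1.4-fold lower number from compound 2 to compound 4 (0.15 log units; within the scatter) is therefore expected to be modest, most likely within the usual scatter, with a slight lean toward a lower number. Compound 4 is estimated at 3000 nM, in the range 900 nM to 10000 nM.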

Compound 4, half-maximal inhibitory concentration: 4000 nM
Compound 4: the middle estimate sits 1.3-fold (0.12 log units) below what was measured, within the range that was stated.
By their numbers in this assay, from the lowest: compound 3; then compounds 4 and 2 (each within the scatter of the next). At a limit, above all of these: compound 1.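

In this assay, among these compounds, the phenyl to 4-fluorophenyl change now stands alone on one core, which no earlier pair allowed: a 1.1-fold lower number from compound 2 to compound 4 (0.02 log units; within the scatter). On this core, fluoro in place of hydrogen on the aromatic carbon para to a large group therefore leaves the read-out within the scatter. Compound 3 at 100 nM and compound 4 at 4000 nM both carry the 4-fluorophenyl, so that group alone does not set the value of compound 3, and no measurement shown gives a reason for the flat step.

Still open, going by these compounds, is whether a chlorine, a methoxy group or an amine in place of the fluoro would move the number on this core. Also open is whether the same change behaves alike on the core of compound 3, where the plain phenyl partner is absent from the compounds shown.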